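The compounds below may be only part of what the source reports. "The series", "measured", "known", "first", "only" and "open" are said of these compounds alone.

The measured compounds, with their results in a functional assay on HL-60 cells (Homo sapiens) for inhibition; on this read-out higher numbers stand for weaker inhibition and lower numbers for stronger inhibition:
Compound 1 `COc1cc(/C=C\c2ccc3ccccc3c2)cc([N+](=O)[O-])c1OC`: 340 nM
Compound 2 `COc1cc(/C=C\c2ccc3ccccc3c2)cc(N)c1OC`: 330 nM
Compound 3 `COc1cc(/C=C\c2ccc3ccccc3c2)cc(NC(C)=O)c1OC`: here the assay reports only a limit, > 5000 nM.

Compound 2 holds the lowest of the two actual numbers, with compound 1 lying within the scatter of it at a 1.0-fold lower number from compound 1 to compound 2 (0.01 log units; within the scatter); the remaining value is a limit. Compound 4 `COc1c(N)cc(/C=C\c2ccc3ccccc3c2)cc1N` differs from compound 2 by amino in place of methoxy on an aromatic carbon, on an aromatic carbon ortho to a methoxy group and meta to an amino group. Going by the values given here, no measured step touches a methoxy group, so none bears directly on this change. The measured steps instead concern the nitrogen-bearing position: a 1.0-fold lower number from compound 1 to compound 2 (0.01 log units; within the scatter) was within the scatter, whereas an at least 14-fold higher number from compound 1 to compound 3 (1.16 log units; beyond the scatter) and an at least 15-fold higher number from compound 2 to compound 3 (1.18 log units; beyond the scatter) were large losses, running up to the limit of > 5000 nM in this assay, at which 1 of the 3 values shown sits. With the methoxy position untested, the step from compound 2 to compound 4 is expected to be a moderate weakening, a 3.0-fold higher number from compound 2 to compound 4 (0.48 log units; beyond the scatter), with wide uncertainty. Compound 4 is therefore estimated at 1000 nM in this assay, within 300 nM to 4000 nM.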

Compound 4, half-maximal inhibitory concentration: 5000 nM
The estimate for compound 4 lay 5.0-fold (0.70 log units) below the measured number; the whole stated range lies below it.
By their numbers in this assay, from the lowest: compounds 2 and 1 (each within the scatter of the next); then compound 4.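

In this assay, going by these compounds alone, the first change at a methoxy position proves far from neutral: amino in place of methoxy gives a 15-fold higher number from compound 2 to compound 4 (1.18 log units; beyond the scatter). An amino group is therefore not interchangeable across the shared core, since amino in place of nitro at the other nitrogen-bearing place gave only a 1.0-fold lower number from compound 1 to compound 2 (0.01 log units; within the scatter). Compound 3 has only a limit, so its order relative to compound 4 cannot be read: the limit of > 5000 nM in this assay, at which 1 of the 4 values shown sits.

The compounds shown do not separate the loss of the methoxy group from the arrival of the amino group. A hydrogen, a hydroxyl or an ethoxy group at this place would help to tell these apart, and an acetamido group here would show whether the step seen at the other nitrogen-bearing place recurs.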